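Methyl on the thiazole amide of the shared core

This account rests on a few compounds, and the source may have more. Where it says the series, first, only, none or still open, it means among the compounds named here.

Measured so far:
- compound 1, `CCCOc1cc(C)c2c(c1C)CC(C(C)C(=O)NCc1cccs1)CC2`: in a functional assay for inhibition of Polyunsaturated fatty acid 5-lipoxygenase (Homo sapiens) (on this read-out higher numbers stand for weaker inhibition and lower numbers for stronger inhibition), compound 1 gives 8000 nM
- compound 2, `CCCOc1cc(C)c2c(c1C)CC(C(C)C(=O)Nc1nccs1)CC2`: in this assay compound 2 gives 800 nM

Among the compounds with values here, compound 2 carries the lower of the two numbers; the only measured step, a 10-fold lower number from compound 1 to compound 2 (1.00 log units; beyond the scatter), separates it from compound 1 and lies beyond the scatter.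

Compound 3, `CCCOc1cc(C)c2c(c1C)CC(C(C)C(=O)Nc1ncc(C)s1)CC2`, keeps the core and amide of compound 2 and changes one point: methyl in place of hydrogen on an aromatic carbon, that is, 1,3-thiazol-2-yl becomes 5-methyl-1,3-thiazol-2-yl, on the ring carbon next to the ring sulfur.

Within the data shown here, no measured pair touches the substitution of that five-membered ring; the single step from compound 1 to compound 2 exchanges the whole group on the amide nitrogen and says nothing about a methyl on the ring that is kept. Among the measured compounds shown here, a small added group of this kind, with no precedent here, is expected to leave this assay about where compound 2 stands, without a shift beyond the scatter: no change at the digits printed from compound 2 to compound 3 (within the scatter).

Compound 3 is therefore estimated at 800 nM, with a range of 300 nM to 2500 nM.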

Compound 3, half-maximal inhibitory concentration: 1000 nM
Estimate against measurement, compound 3: 1.3-fold (0.10 log units) below; measured number inside the range.
By their numbers in this assay, from the lowest: compounds 2 and 3 (each within the scatter of the next); then compound 1.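

In this assay, methyl in place of hydrogen on the aromatic carbon next to the ring sulfur gives a 1.3-fold higher number from compound 2 to compound 3 (0.10 log units; within the scatter), so this position accepts a methyl with no shift that can be told from the scatter. The drop in the number that came with the thiazole amide also holds with the methyl in place: 5-methyl-1,3-thiazol-2-yl in place of (thiophen-2-yl)methyl on the amide-type nitrogen gives an 8.0-fold lower number from compound 1 to compound 3 (0.90 log units; beyond the scatter), beyond the scatter, as was a 10-fold lower number from compound 1 to compound 2 (1.00 log units; beyond the scatter). Nothing available on this series bears on why the methyl leaves this assay within the scatter.

Within the data shown here, a single methyl is the only group seen on this ring carbon, so it remains open whether a longer chain such as propyl, a carboxylic acid or an amine at the same place would also stay within the scatter of compound 2 or would move the number beyond it. Going by these compounds, it also remains open how a pyridin-2-yl on the amide-type nitrogen, in place of the 1,3-thiazol-2-yl of compound 2, would read in this assay.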